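The source may report more compounds than this note shows. Statements on the series, on what has been measured and on what is new or still open speak of the compounds shown alone.

Three compounds have so far been measured in an assay on microsomes from brain for inhibition of Fatty-acid amide hydrolase 1 (Rattus norvegicus), read by fluorescence and HPLC, with a stated time of 45 min; a lower number here means a stronger inhibitor, a higher number a weaker inhibitor:

compound 1, `O=C(COc1ccc(Oc2ccccc2)cc1)Cn1ncnn1`, gives 8 nM
compound 2, `N#CNC(COc1ccc(Oc2ccccc2)cc1)Cn1ncnn1`, gives 5300 nM
compound 3, `CC(=O)Nc1ccc2c(cnn2CC(=O)COc2ccc(Oc3ccccc3)cc2)c1`, gives 3900 nM

Compound 3 stands second highest of these three numbers. Its nearest neighbour is compound 2, whose value lies within the usual scatter of that of compound 3; compound 1 lies far lower, well beyond the scatter.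

Compound 4, `O=C(COc1ccc(Oc2ccccc2)cc1)Cn1ncc2cc(NC(=O)CO)ccc21`, differs from compound 3 by hydroxy in place of hydrogen on a saturated chain carbon bound to a carbonyl carbon. Among the compounds with values here, no pair of measured compounds shows this change, so there is no measured step to lean on. With so small an alteration, the step expected from compound 3 to compound 4 is a 1.1-fold lower number from compound 3 to compound 4 (0.05 log units; within the scatter), none beyond the scatter in either direction. Compound 4 is therefore estimated at 3500 nM, with a range from 1200 nM to 10000 nM.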

Compound 4, half-maximal inhibitory concentration: 5400 nM
The estimate for compound 4 lay 1.5-fold (0.19 log units) below the measured number, and the stated range covers the measured number.
By their numbers in this assay, from the lowest: compound 1; then compounds 3, 2 and 4 (each within the scatter of the next).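

Putting hydroxy in place of hydrogen on a saturated chain carbon bound to a carbonyl carbon, which turns acetamido into ((hydroxymethyl)carbonyl)amino, gives a 1.4-fold higher number from compound 3 to compound 4 (0.14 log units; within the scatter) in this assay. Within the data shown here, this is the first measured step at this position, and it shows that the change leaves compound 3 and compound 4 within the scatter of each other. One step at one place cannot show how far this holds. As far as these compounds go, whether an amine, a carboxylic acid or a longer chain at this place would move the number beyond the scatter remains open. No evidence bearing on this result is available here.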